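Benzyl for butoxy on the urea aryl ring

This account rests on a few compounds, and the source may have more. Where it says the series, first, only, none or still open, it means among the compounds named here.

Compound 2 `CCCCOc1ccc(NC(=O)n2nc(N)c3ccccc32)cc1` gives 14500 nM in a functional assay on MCF7 cells (Homo sapiens) for inhibition, read by sulforhodamine B assay, with a stated time of 48 h (on this read-out lower numbers stand for stronger inhibition of growth and higher numbers for weaker inhibition of growth), the lowest of the two numbers reported there; its nearest neighbour, compound 3 `Nc1nn(C(=O)Nc2c(F)cccc2F)c2ccccc12`, gives 60000 nM in this assay, a gap beyond the usual scatter. Compound 1 `COc1ccc(NC(=O)Nc2n[nH]c3ccccc23)cc1` reaches only a limit of this assay, > 100000 nM, as the limit of > 100000 nM in this assay, at which 1 of the 3 values shown sits, shows. Compound 4 `Nc1nn(C(=O)Nc2ccc(Cc3ccccc3)cc2)c2ccccc12` is not yet measured; it differs from compound 2 by benzyl in place of butoxy on an aromatic carbon. Among the compounds with values here, no measured pair differs in this one place, so no step size is known for it, and the values shown give no ground to expect a shift beyond the scatter in either direction in this assay. Compound 4 is therefore expected near 12000 nM, between 4000 nM and 40000 nM. This estimate implies an expected step of a 1.2-fold lower number from compound 2 to compound 4 (0.08 log units; within the scatter).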

Compound 4, concentration for 50% growth inhibition: 555 nM
Estimate against measurement, compound 4: 22-fold (1.33 log units) above, outside the stated range (below it).
By their numbers in this assay, from the lowest: compound 4; then compound 2; then compound 3. At a limit, above all of these: compound 1.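

In this assay, the aromatic carbon para to a large group proves sensitive to what it carries: benzyl in place of butoxy gives a 26-fold lower number from compound 2 to compound 4 (1.42 log units; beyond the scatter) on the shared core. Within the data shown here, this is the first measured change at this place, and it shows that a single substituent swap there can move growth inhibition well beyond the scatter. No measurement shown bears on why this step is so large.

From the compounds shown here alone, whether the step follows from the added aromatic ring or from the lost ether oxygen stays open. A phenoxy or cyclohexylmethyl group at this place would separate the two.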